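Replacing the (cyanomethyl)carbamoyl group of compound 1

The source may report more compounds than this note shows. Statements on the series, on what has been measured and on what is new or still open speak of the compounds shown alone.

In a functional assay on MIA PaCa-2 cells (Homo sapiens) for antiproliferative activity (on this read-out higher numbers stand for an effect only at larger amounts of compound and lower numbers for an effect already at smaller amounts), compound 1 `Cc1cc2c(C(=O)NCC#N)cccc2n1-c1nc2c(c(NCc3ccccc3)n1)CCCC2` gives 468 nM. Compound 3 `CC#CC(=O)Nc1cccc2c1cc(C)n2-c1nc2c(c(NCc3ccccc3)n1)CCCC2` gives 436 nM, which cannot be told apart from that, and compound 2 `C#CC(=O)Nc1cccc2c1cc(C)n2-c1nc2c(c(NCc3ccccc3)n1)CCCC2` gives 131 nM, which is a 3.6-fold lower number from compound 1 to compound 2 (0.55 log units; beyond the scatter).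

Compound 4 `CCC#CC(=O)Nc1cccc2c1cc(C)n2-c1nc2c(c(NCc3ccccc3)n1)CCCC2` replaces the (cyanomethyl)carbamoyl on the same aromatic carbon: a group of 7 heavy atoms (5 carbon, 1 nitrogen, 1 oxygen; no ring) in place of a group of 6 heavy atoms (3 carbon, 2 nitrogen, 1 oxygen; no ring), on an aromatic carbon. Its entering group is larger than that of compound 3, the nearest comparison, which shows a 1.1-fold lower number from compound 1 to compound 3 (0.03 log units; within the scatter). Methyl in place of hydrogen on a triple-bonded carbon gave a 3.3-fold higher number from compound 2 to compound 3 (0.52 log units; beyond the scatter), so a further rise in the number seems possible. In this assay no step beyond the scatter is expected, with any drift upward. The expected step is a 1.3-fold higher number from compound 1 to compound 4 (0.11 log units; within the scatter). Compound 4 is estimated at 600 nM, within 250 nM to 1500 nM.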

Compound 4, half-maximal effective concentration: 463 nM
The estimate for compound 4 lay 1.3-fold (0.11 log units) above the measured number, and the stated range covers the measured number.
By their numbers in this assay, from the lowest: compound 2; then compounds 3, 4 and 1 (each within the scatter of the next).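

On the triple-bonded carbon, ethyl cannot be told apart from methyl (a 1.1-fold higher number from compound 3 to compound 4 (0.03 log units; within the scatter)), while ethyl in place of hydrogen stays beyond the scatter (a 3.5-fold higher number from compound 2 to compound 4 (0.55 log units; beyond the scatter)), so the second added carbon brings no further rise. The entering group of 7 heavy atoms also matches the (cyanomethyl)carbamoyl (a 1.0-fold lower number from compound 1 to compound 4 (0.00 log units; within the scatter)), leaving compound 2 alone apart from the others in this assay at this aromatic carbon. Nothing available explains this flat response.

Going by these compounds, whether a longer chain on the triple-bonded carbon stays level remains open. So does whether an amine at the end of that chain, or a saturated propanoylamino group, would approach compound 2.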